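Acetylpyrazoline series: hydroxy in place of nitro

The compounds below may be only part of what the source reports. "The series", "measured", "known", "first", "only" and "open" are said of these compounds alone.

Compound 1 `COc1cccc(C2CC(c3cc(OC)c(OC)c(OC)c3)=NN2C(C)=O)c1` and compound 2 `COc1ccc(C2CC(c3cc(OC)c(OC)c(OC)c3)=NN2C(C)=O)cc1[N+](=O)[O-]` share one core and differ only in the substitution of the pendant ring. In a functional assay on L1210 cells (Mus musculus) for cytotoxicity, read by MTT assay, with a stated time of 72 h (a lower number here means a stronger inhibitor, a higher number a weaker inhibitor), compound 1 gives 44000 nM, and compound 2 gives 52000 nM. Compound 2 carries the highest of the two numbers shown, but compound 1 stands within the scatter of it, so the two cannot be ordered. Compound 3 `COc1ccc(C2CC(c3cc(OC)c(OC)c(OC)c3)=NN2C(C)=O)cc1O` is not yet measured. It differs from compound 2 by hydroxy in place of nitro on an aromatic carbon, placed on an aromatic carbon of a six-membered aromatic ring of carbon only, ortho to a methoxy group. Within the data shown here, no step between measured compounds tells how large a move to expect here. A drop in this assay, beyond the scatter, is expected, by a 4.3-fold lower number from compound 2 to compound 3 (0.64 log units; beyond the scatter). Compound 3 is estimated at 12000 nM, with a range from 2000 nM to 50000 nM.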

Compound 3, half-maximal inhibitory concentration: > 100000 nM
Compound 3 was reported as a limit; the forecaster's own chance of this, stated with the estimate: 5%; at least 8.3-fold (0.92 log units) between middle value and limit.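

In this assay compound 3 gives > 100000 nM, which is a limit of the assay and not a number. Hydroxy in place of nitro on this aromatic carbon, ortho to a methoxy group, gives an at least 1.9-fold higher number from compound 2 to compound 3 (0.28 log units; that floor lies within the scatter), so this floor alone does not separate the two compounds, while 3-hydroxy-4-methoxyphenyl in place of 3-methoxyphenyl gives an at least 2.2-fold higher number from compound 1 to compound 3 (0.35 log units; beyond the scatter), the only step here beyond the scatter, and it points towards a weaker inhibitor. Both steps are floors, because the value of compound 3 is a limit: the limit of > 100000 nM in this assay, at which 1 of the 3 values shown sits.

As far as these compounds go, the true size of both steps therefore stays open, as does whether hydroxy costs anything relative to nitro at this position. From the compounds shown here alone, whether an amine or a fluorine on the same aromatic carbon would give a lower number is also open.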